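The compounds below may be only part of what the source reports. "The series", "measured", "known", "first", "only" and "open" are said of these compounds alone.

Compound 1 `CC(C)C[C@H](N)c1cc(C(F)(F)F)ccc1N1CCN(C(=O)COc2ccc3ccccc3c2)CC1` is a member of a small set tested in an assay on HEK293 cells for displacement of a labelled ligand from Melanocortin receptor 4 (Homo sapiens) (a higher number here means a weaker inhibitor, a lower number a stronger inhibitor), where compound 1 gives 2000 nM. Among the three measured compounds this is the second highest number. Compound 3 `CC(C)C[C@H](N)c1cc(C(F)(F)F)ccc1N1CCN(C(=O)COc2cccc(Cl)c2Cl)CC1` gives 2500 nM, a change of a 1.3-fold higher number from compound 1 to compound 3 (0.10 log units; within the scatter); compound 2 `COc1cc(CC(C)C(=O)N2CCN(c3ccc(C(F)(F)F)cc3[C@@H](N)CC(C)C)CC2)ccc1Cl` gives 230 nM, a change of an 8.7-fold lower number from compound 1 to compound 2 (0.94 log units; beyond the scatter).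

The unmeasured compound 4 `COc1ccc(CC(C)C(=O)N2CCN(c3ccc(C(F)(F)F)cc3[C@@H](N)CC(C)C)CC2)cc1F` differs from compound 1 in one place: 1-(3-fluoro-4-methoxybenzyl)ethyl in place of ((naphthalen-2-yl)oxy)methyl on a carbonyl carbon.

For the measured compounds named here, two measured steps bear on this. The step from compound 1 to compound 2 replaced the same ((naphthalen-2-yl)oxy)methyl group on the carbonyl carbon with a 1-(4-chloro-3-methoxybenzyl)ethyl group and gave an 8.7-fold lower number from compound 1 to compound 2 (0.94 log units; beyond the scatter), and the reverse kind of swap, an 11-fold higher number from compound 2 to compound 3 (1.04 log units; beyond the scatter), points the same way. Going by the values given here, compound 4 carries a 1-(3-fluoro-4-methoxybenzyl)ethyl group instead, so the halogen and the methoxy group are arranged differently than in compound 2, and no measured compound shows how much that matters. A lower number than for compound 1 is therefore expected, probably not quite as far as compound 2 reached. Compound 4 is estimated at 350 nM, with a range from 120 nM to 1000 nM, which means an expected step of a 5.7-fold lower number from compound 1 to compound 4 (0.76 log units; beyond the scatter).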

Compound 4, inhibition constant: 200 nM
Estimate against measurement, compound 4: 1.8-fold (0.24 log units) above; the range from low to high includes it.
By their numbers in this assay, from the lowest: compounds 4 and 2 (each within the scatter of the next); then compounds 1 and 3 (each within the scatter of the next).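

The drop in number at this position in this assay now appears with a second ring pattern, so it does not depend on the 4-chloro-3-methoxyphenyl ring alone: the 1-(3-fluoro-4-methoxybenzyl)ethyl group on the carbonyl carbon gives a 10-fold lower number from compound 1 to compound 4 (1.00 log units; beyond the scatter), and a 13-fold lower number from compound 3 to compound 4 (1.10 log units; beyond the scatter) when it replaces (2,3-dichlorophenoxy)methyl. The two rings themselves cannot be told apart here, with a 1.2-fold lower number from compound 2 to compound 4 (0.06 log units; within the scatter), even though the halogen differs and it is arranged differently with the methoxy group. In these four compounds, then, both 1-benzylethyl-type groups give clearly lower numbers than both phenoxy-type or naphthyloxy-type methyl groups, whichever ring each carries.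

Nothing measured here explains this difference. The swap changes the ether oxygen, the branching and the ring together, so the compounds shown leave open which of these matters, and also how a ring carrying a nitrile or a plain unsubstituted benzyl group would behave in this place.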